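The source may hold more compounds than are shown below. What is called first, only, known or untested is meant among the compounds shown, and "the series" means these compounds.

Measured compounds in a functional assay on the whole organism for inhibition, with Rattus norvegicus as the target, read by paw edema, at a dose of 100 mg/kg by the oral route; on this read-out higher numbers stand for more inhibition at the one dose given (going by the name of the read-out) and lower numbers for less inhibition:
compound 1 `CCOC(=O)c1c(O)c2cccnc2n(-c2ccccc2)c1=O` — 23.5%
compound 2 `Cc1cccc(NC(=O)c2c(O)c3cccnc3n(-c3ccccc3)c2=O)c1` — 14.2%

Going by the values given here, of the two numbers in hand, that of compound 1 is the one the next step is taken from; compound 2 differs from it only by (3-methylphenyl)amino in place of ethoxy on a carbonyl carbon, and the two values lie within the scatter of each other, the change being a number 9.3 percentage points lower from compound 1 to compound 2 (within the scatter). Nothing in these two numbers separates an ester from an amide at this position.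

Compound 3 `O=C(NCc1cccnc1)c1c(O)c2cccnc2n(-c2ccccc2)c1=O` is not yet measured in this assay. Against compound 1 the difference is ((pyridin-3-yl)methyl)amino in place of ethoxy on a carbonyl carbon. Among the compounds with values here, the only measured step that bears on this is the one from compound 1 to compound 2, which also puts an amino group on the same carbonyl carbon and stayed within the scatter. The step from compound 1 to compound 3 is therefore expected to be small as well, tending if anything toward a lower number, a number 6.5 percentage points lower from compound 1 to compound 3 (within the scatter). For compound 3 the expected value in this assay is 17%, estimated to fall between 5% and 29%.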

Compound 3, a percentage reported as inhibition, in the whole organism at one dose (the size of the read-out at that dose, not a potency): 25.5%
Compound 3: the middle estimate sits 8.5 percentage points below what was measured; the measured number falls inside the stated range.
By their numbers in this assay, from the lowest: compounds 2, 1 and 3 (each within the scatter of the next, the first and the last beyond it).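

In this assay, ((pyridin-3-yl)methyl)amino in place of ethoxy on the carbonyl carbon gives a number 2 percentage points higher from compound 1 to compound 3 (within the scatter), so an amide at this position carrying a six-membered aromatic ring with one hetero atom reads the same as the ester within the scatter. Going by these compounds alone, the group on the amide-type nitrogen is the first change to separate two compounds: (pyridin-3-yl)methyl in place of 3-methylphenyl gives a number 11.3 percentage points higher from compound 2 to compound 3 (beyond the scatter), a modest step, while neither amide is separated from the ester. No measurement available here accounts for this step.

From the compounds shown here alone, this exchange alters the ring and adds a methylene link in one move, so it remains open whether the ring nitrogen or the link carries the step, which a benzyl group on the amide-type nitrogen would help to separate. Also open, going by these compounds, is how far this position extends beyond esters and amides, for instance to the free carboxylic acid, and whether the pyridin-2-yl or pyridin-4-yl isomers of the (pyridin-3-yl)methyl group read alike at this single oral dose.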